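The compounds below may be only part of what the source reports. "The series", "measured", "known", "first", "only" and "open" are said of these compounds alone.

In a functional assay on K562 cells (Homo sapiens) for cytotoxicity, read by MTT assay, with a stated time of 72 h (on this read-out higher numbers stand for weaker inhibition and lower numbers for stronger inhibition), compound 1 `C=C1C(=O)[C@@]23C(=O)OC[C@]4(C(=O)CCC(C)(C)[C@H]4C=O)[C@@H]2CC[C@@H]1[C@H]3O` gives 2180 nM, compound 2 `C=C1C(=O)[C@@]23C(=O)OC[C@]4(C(=O)CCC(C)(C)[C@H]4C=O)[C@@H]2CC[C@@H]1[C@H]3OC(=O)c1ccc(F)cc1` gives 2700 nM, and compound 3 `C=C1C(=O)[C@@]23C(=O)OC[C@]4(C(=O)CCC(C)(C)[C@H]4C=O)[C@@H]2CC[C@@H]1[C@H]3OC(=O)c1ccc(Cl)cc1` gives 1380 nM. Compound 3 therefore stands within the scatter of both others, with a 1.6-fold lower number from compound 1 to compound 3 (0.20 log units; within the scatter) and a 2.0-fold lower number from compound 2 to compound 3 (0.29 log units; within the scatter). Compound 4 `C=C1C(=O)[C@@]23C(=O)OC[C@]4(C(=O)CCC(C)(C)[C@H]4C=O)[C@@H]2CC[C@@H]1[C@H]3OC(=O)c1ccccc1Cl` differs from compound 3 as follows: 2-chlorophenyl in place of 4-chlorophenyl on a carbonyl carbon, with 2-chlorophenyl in place of 4-chlorophenyl on a carbonyl carbon. Among the measured compounds shown here, no measured step compares these two groups. The closest evidence is a 2.0-fold lower number from compound 2 to compound 3 (0.29 log units; within the scatter), together with a 1.2-fold higher number from compound 1 to compound 2 (0.09 log units; within the scatter), and each of these stays within the scatter. No change beyond the scatter is therefore expected in this assay. The estimated step is a 1.3-fold higher number from compound 3 to compound 4 (0.12 log units; within the scatter). For compound 4, the estimated value is 1800 nM, expected to lie between 900 nM and 3600 nM.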

Compound 4, half-maximal inhibitory concentration: 1220 nM
Estimate against measurement, compound 4: 1.5-fold (0.17 log units) above, and the stated range covers the measured number.
By their numbers in this assay, from the lowest: compounds 4, 3, 1 and 2 (each within the scatter of the next, the first and the last beyond it).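

Placing the chloro on the carbonyl-bound phenyl as 2-chlorophenyl rather than 4-chlorophenyl keeps the two compounds within the scatter in this assay, with a 1.1-fold lower number from compound 3 to compound 4 (0.05 log units; within the scatter). Set against 4-fluorophenyl, however, 2-chlorophenyl gives the only modest step beyond the scatter so far, a 2.2-fold lower number from compound 2 to compound 4 (0.35 log units; beyond the scatter), whereas against hydrogen on that oxygen it stays within the scatter, with a 1.8-fold lower number from compound 1 to compound 4 (0.25 log units; within the scatter). Nothing at hand accounts for this difference. The compounds shown leave open how a phenyl carrying an amine or a carboxylic acid, or a longer chain in place of the phenyl, would read in this assay.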